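This account rests on a few compounds, and the source may have more. Where it says the series, first, only, none or still open, it means among the compounds named here.

Compound 1, `Cc1c(Cc2ccccc2S(=O)(=O)c2ccccc2F)c2c(n1CC(=O)O)CCNC2=O`, in a functional assay on CHO.K1 cells for antagonist activity at prostaglandin D2 receptor 2 (Homo sapiens), read by GTPgammaS binding, with a stated time of 1 h (a lower number here means a stronger inhibitor, a higher number a weaker inhibitor), gives 3.6 nM.
Compound 2, `Cc1c(Cc2ccccc2S(=O)(=O)c2cccc(Cl)c2)c2c(n1CC(=O)O)CCNC2=O`, in this assay gives 4 nM.
Compound 3, `Cc1c(Cc2ccccc2S(=O)(=O)c2ccc(F)cc2)c2c(n1CC(=O)O)CCNC2=O`, in this assay gives 3.3 nM.

Among these three, compound 3 gives the lowest number, but the steps of a 1.1-fold lower number from compound 1 to compound 3 (0.04 log units; within the scatter) and a 1.2-fold lower number from compound 2 to compound 3 (0.08 log units; within the scatter) both lie within the scatter, so no order among the three can be claimed. All three share the same core and differ only in the phenyl ring on the sulfonyl sulfur.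

Compound 4, `Cc1c(Cc2ccccc2S(=O)(=O)c2ccc(Cl)cc2)c2c(n1CC(=O)O)CCNC2=O`, continues this series with one change from compound 3: chloro in place of fluoro on an aromatic carbon. Going by the values given here, every measured step so far has altered this same phenyl ring, exchanging one halogen or its position for another: a 1.1-fold higher number from compound 1 to compound 2 (0.05 log units; within the scatter), a 1.1-fold lower number from compound 1 to compound 3 (0.04 log units; within the scatter) and a 1.2-fold lower number from compound 2 to compound 3 (0.08 log units; within the scatter) were all within the scatter. On that basis the expected step of a 1.1-fold higher number from compound 3 to compound 4 (0.03 log units; within the scatter) in this assay is none beyond the scatter. Compound 4 is therefore estimated at 3.5 nM, with a range from 1.7 nM to 7 nM.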

Compound 4, half-maximal inhibitory concentration: 8.5 nM
For compound 4 the middle estimate is 2.4-fold (0.39 log units) below the measured one; measured number outside the range, above it.
By their numbers in this assay, from the lowest: compounds 3, 1 and 2 (each within the scatter of the next); then compound 4.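

Going by these compounds alone, earlier swaps on this phenyl ring all stayed within the scatter, so they gave no sign that the ring could shift the number; chloro in place of fluoro, para to a large group, now gives a 2.6-fold higher number from compound 3 to compound 4 (0.41 log units; beyond the scatter) in this assay and is the first step here to pass the scatter. The other two comparisons point the same way, with a 2.1-fold higher number from compound 2 to compound 4 (0.33 log units; beyond the scatter) for 4-chlorophenyl in place of 3-chlorophenyl and a 2.4-fold higher number from compound 1 to compound 4 (0.37 log units; beyond the scatter) for 4-chlorophenyl in place of 2-fluorophenyl, so compound 4 is the weakest of the four, though only modestly. Nothing here explains this shift.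

As far as these compounds go, it remains open whether bromo, methyl or methoxy in the same place would follow fluoro or chloro. A plain phenyl and a 2-chlorophenyl also remain to be placed against these numbers.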